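Series notes: from compound 3 to compound 4

The source may hold more compounds than are shown below. What is called first, only, known or untested is meant among the compounds shown, and "the series" means these compounds.

Among the compounds with values here, the three measured members share one core and differ only in the substituted phenyl carried on a nitrogen on an aromatic ring: compound 1 `CN1CCN(CCCOc2cccc3nc(Nc4ccc(F)c(F)c4)ccc23)CC1`, compound 2 `CN1CCN(CCCOc2cccc3nc(Nc4cccc(Cl)c4)ccc23)CC1` and compound 3 `CN1CCN(CCCOc2cccc3nc(Nc4ccc(Cl)c(F)c4)ccc23)CC1`. In a functional assay on NCI-H522 cells (Homo sapiens) for inhibition, read by sulforhodamine B assay, with a stated time of 48 h (a lower number here means a stronger inhibitor of growth, a higher number a weaker inhibitor of growth), compound 1 gives 1010 nM, compound 2 gives 1480 nM and compound 3 gives 1750 nM. Compound 3 therefore holds the highest of the three numbers, nearest to compound 2 and furthest from compound 1, but every gap lies within the scatter. The pairwise steps say the same: a 1.5-fold higher number from compound 1 to compound 2 (0.17 log units; within the scatter), a 1.7-fold higher number from compound 1 to compound 3 (0.24 log units; within the scatter) and a 1.2-fold higher number from compound 2 to compound 3 (0.07 log units; within the scatter). Compound 4 `CN1CCN(CCCOc2cccc3nc(Nc4ccc(Cl)c(C(F)(F)F)c4)ccc23)CC1` is the next member; its change from compound 3 is trifluoromethyl in place of fluoro on an aromatic carbon. The most direct precedent is the exchange of one halogen for another on this phenyl in a 1.7-fold higher number from compound 1 to compound 3 (0.24 log units; within the scatter), which stayed within the scatter, as did the other two exchanges, so the present change is expected to leave the number essentially unmoved. Compound 4 is estimated at 1800 nM, with a range of 700 nM to 4500 nM. The expected step is a 1.0-fold higher number from compound 3 to compound 4 (0.01 log units; within the scatter).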

Compound 4, concentration for 50% growth inhibition: 1830 nM
Compound 4: middle estimate off by 1.0-fold (0.01 log units), on the low side; the measured number falls inside the stated range.
By their numbers in this assay, from the lowest: compounds 1, 2, 3 and 4 (each within the scatter of the next).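

In this assay, the exchange on the aromatic carbon ortho to a chloro group brings in 4 heavy atoms in place of 1 heavy atom, yet trifluoromethyl in place of fluoro gives a 1.0-fold higher number from compound 3 to compound 4 (0.02 log units; within the scatter) and this carbon takes a bulkier substituent than any earlier member carried there without a step beyond the scatter. The wider comparisons, a 1.2-fold higher number from compound 2 to compound 4 (0.09 log units; within the scatter) and a 1.8-fold higher number from compound 1 to compound 4 (0.26 log units; within the scatter), also stay within the scatter, so the 4-chloro-3-(trifluoromethyl)phenyl group cannot be told apart from the other two phenyl groups it is compared with here. No measurement at hand bears on why this response is so flat.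

Going by these compounds, whether an amine, a carboxylic acid or a longer chain on this carbon would also leave the number in place remains open. Also open, on these data alone, is whether trifluoromethyl would behave the same way without the chloro group.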